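A few compounds are considered here, and "the series" means these few. Any claim that something is new, unique, unknown or untested is made for them only; others in the source may bear on it.

Measured so far:
- compound 1 `CCc1ccc(C(=O)NC(=O)c2ccccc2O)cc1`: 70 ug/mL
- compound 2 `CS(=O)(=O)c1ccc(C(=O)NC(=O)c2ccccc2O)cc1`: a limit, > 100 ug/mL

Going by the values given here, in an ADME assay on L6 cells (Rattus norvegicus) for cytotoxicity, read by resazurin assay, with a stated time of 72 h (on this read-out higher numbers stand for weaker inhibition and lower numbers for stronger inhibition), compound 1 gives 70 ug/mL, which is the only outright number among the two readings. For compound 2 the reading is not a number but a limit, namely (the limit of > 100 ug/mL in this assay, at which 1 of the 2 values shown sits). Among the compounds with values here, the one measured step, an at least 1.4-fold higher number from compound 1 to compound 2 (0.15 log units; that floor lies within the scatter), replaces ethyl with methylsulfonyl on an aromatic carbon, and its floor is small enough to sit within the scatter, so it shows at most a mild weakening.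

Compound 3 `Nc1ccc(C(=O)NC(=O)c2ccccc2O)cc1` is not yet measured. It differs from compound 1 by amino in place of ethyl on an aromatic carbon. Within the data shown here, the only step that bears on this change is the one from compound 1 to compound 2, where a different group also took the place of ethyl on the same aromatic carbon, and it gave a small or no change. By the same token the step to compound 3 is expected to be small, a 1.2-fold higher number from compound 1 to compound 3 (0.08 log units; within the scatter), leaning if anything toward a higher number. Compound 3 is therefore estimated at 85 ug/mL, with a range from 40 ug/mL to 180 ug/mL.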

Compound 3, half-maximal inhibitory concentration: 39 ug/mL
For compound 3 the middle estimate is 2.2-fold (0.34 log units) above the measured one; the whole stated range lies above it.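

In this assay, going by these compounds alone, this position on the aromatic carbon now gives a step beyond the usual scatter for the first time, an at least 2.5-fold lower number from compound 2 to compound 3 (0.40 log units; beyond the scatter), with amino in place of methylsulfonyl, so the choice of group here can shift the reading in these cells. Amino in place of ethyl gives a 1.8-fold lower number from compound 1 to compound 3 (0.25 log units; within the scatter), which cannot be told apart from the differences seen between repeated measurements, so ethyl and amino are not separated on this evidence. The reading for compound 2 is a limit and not a number: the limit of > 100 ug/mL in this assay, at which 1 of the 3 values shown sits.

Going by these compounds, with only ethyl, methylsulfonyl and amino at this position, it stays open how a carboxylic acid, a longer chain such as butyl, or a methylamino group would read in this assay. The three readings also say nothing about why amino and methylsulfonyl differ, or whether the same swap would give a similar step at another place on the shared core.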